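This account rests on a few compounds, and the source may have more. Where it says the series, first, only, none or still open, it means among the compounds named here.

Compound 1 `CC1=C(C(=O)Nc2ccc(F)cc2)C(c2ccc([N+](=O)[O-])cc2)N=C(SCc2ccccc2)N1` is the starting point of this small series. In a functional assay on the whole organism (artery, strain albino) with Rattus norvegicus as the target, with a stated time of 240 min, at a dose of 10 mg/kg by the oral route (a higher number here means more inhibition at the dose given (going by the name of the read-out), a lower number less inhibition), compound 1 gives 32.3%. Compound 2 `CC1=C(C(=O)Nc2ccc(F)cc2)C(c2ccc([N+](=O)[O-])cc2)N=C(SCc2cccc(Cl)c2)N1` differs from it in one place, (chloro in place of hydrogen on an aromatic carbon). In this assay compound 2 gives 15.9%, and the change brought a number 16.4 percentage points lower from compound 1 to compound 2 (beyond the scatter).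

Compound 3 `CC1=C(C(=O)Nc2ccc(Br)cc2)C(c2ccc(Cl)cc2Cl)N=C(SCc2ccccc2)N1` carries a different core; the difference between the two cores is not broken down here. In this assay compound 3 gives 17.4%, which lies second highest of the three numbers: its gap to compound 2 is within the usual scatter, while compound 1 stands beyond the scatter above it.

Compound 4 `CC1=C(C(=O)Nc2ccc(Br)cc2)C(c2ccc(Cl)cc2Cl)N=C(SCc2ccccc2Cl)N1` has not been measured. It differs from compound 3 in one place, (chloro in place of hydrogen on an aromatic carbon). This is the same kind of change as that from compound 1 to compound 2, though not the same: in compound 2 the chloro sits meta to a large group, in compound 4 ortho to a large group. Among the compounds with values here, the single measured example of this kind of change lowered the read-out, and compound 3 already starts from a lower number than compound 1, so a step in the same direction but of smaller size is expected. For compound 4 the expected step is a number 8.4 percentage points lower from compound 3 to compound 4 (within the scatter). In this assay compound 4 is expected to give 9%, estimated to fall between 0% and 20%.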

Compound 4, a percentage reported as inhibition, in the whole organism at one dose (the size of the read-out at that dose, not a potency): 28.7%
The estimate for compound 4 lay 19.7 percentage points below the measured number; the measured number lies above the stated range.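

In this assay, chloro in place of hydrogen on an aromatic carbon did not behave on the core of compound 3 as it had on the core of compound 1: the new step reads a number 11.3 percentage points higher from compound 3 to compound 4 (beyond the scatter), opposite in direction to the earlier one. Set side by side, the two steps show that the result of this change in one pair could not be carried over to the other: the same change on two cores in this assay, a number 16.4 percentage points lower (beyond the scatter) from compound 1 to compound 2 and a number 11.3 percentage points higher (beyond the scatter) from compound 3 to compound 4, 27.7 percentage points apart, beyond the scatter of two such steps

Within the data shown here, this does not show that the core alone reverses the step, since there are only two pairs and the chloro does not sit at the same place in compound 2 and compound 4, so the effects of core and place cannot be told apart here.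

The compounds shown leave open what the same 2-chlorobenzyl group would do on the core of compound 1, and what a chloro placed as in compound 2 would do on the core of compound 3. They also leave open whether the rise belongs to chloro in particular or would also appear with a methoxy group, an amine or a carboxylic acid on the benzyl group, or with a longer chain in its place.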